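This account rests on a few compounds, and the source may have more. Where it says the series, first, only, none or still open, it means among the compounds named here.

The measured compounds and their values:

Compound 1, `Cc1nc(-c2ccccc2)c(C(=O)N2CCN(c3cccc(C(F)(F)F)c3)CC2)o1`, gives 153 nM in a functional assay on HL-60 cells (Homo sapiens) for inhibition, read by MTT assay, with a stated time of 72 h; on this read-out lower numbers stand for stronger inhibition and higher numbers for weaker inhibition.
Compound 2, `Cc1nc(-c2ccccc2)c(C(=O)N2CCN(c3ccccc3)CC2)o1`, gives 39.1 nM in this assay.
Compound 3, `CC(=O)Nc1cccc(N2CCN(C(=O)c3oc(C)nc3-c3ccccc3)CC2)c1`, gives 329 nM in this assay.

Among these three, compound 3 stands at the highest number: compound 1 is nearest, with a 2.2-fold higher number from compound 1 to compound 3 (0.33 log units; beyond the scatter), and compound 2 is furthest, with an 8.4-fold higher number from compound 2 to compound 3 (0.93 log units; beyond the scatter). Compound 4, `Cc1nc(-c2ccccc2)c(C(=O)N2CCN(c3cccc(Cl)c3)CC2)o1`, has not yet been measured in this assay. It differs from compound 3 as follows: chloro in place of acetamido on an aromatic carbon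

For the measured compounds named here, two measured steps bear on this change. Both involve the acetamido group on the same aromatic carbon, and in both the acetamido compound sits at the higher number: an 8.4-fold higher number from compound 2 to compound 3 (0.93 log units; beyond the scatter) and a 2.2-fold higher number from compound 1 to compound 3 (0.33 log units; beyond the scatter). Neither step places chloro there, so the size of the effect of chloro itself is not known from these three compounds. Still, the two steps agree that removing acetamido from that position lowers the number, by a modest amount in one case and a larger one in the other. On that basis, compound 4 is expected to sit between compound 2 and compound 1, giving an estimated 4.1-fold lower number from compound 3 to compound 4 (0.61 log units; beyond the scatter). The estimate for compound 4 in this assay is therefore 80 nM, with a range from 30 nM to 250 nM.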

Compound 4, half-maximal inhibitory concentration: 39.2 nM
Beside the measured number, compound 4's estimate is 2.0-fold (0.31 log units) above it, within the range that was stated.
By their numbers in this assay, from the lowest: compounds 2 and 4 (each within the scatter of the next); then compound 1; then compound 3.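

In this assay, for the compounds shown here, the earlier compounds showed only that trifluoromethyl and acetamido each gave a higher number than hydrogen on this aromatic carbon, so any group there might have been expected to do the same. Compound 4 shows that this does not hold for every group: chloro cannot be told apart from hydrogen at this place, with a 1.0-fold higher number from compound 2 to compound 4 (0.00 log units; within the scatter), so the presence of a group there does not by itself raise the number. The same chloro group separates clearly from the other two, with an 8.4-fold lower number from compound 3 to compound 4 (0.92 log units; beyond the scatter) and a 3.9-fold lower number from compound 1 to compound 4 (0.59 log units; beyond the scatter), which shows that the outcome at this position depends on which group sits there, although nothing given here accounts for the difference between these groups.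

These four compounds leave open how other groups on this carbon, such as an amine, a carboxylic acid or a methoxy group, would compare with chloro and hydrogen. They also leave open whether chloro would match hydrogen on another carbon of the same ring, or with a different substituent elsewhere on the shared core.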